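Nitro in place of chloro: expected total growth inhibition

The compounds below may be only part of what the source reports. "The series", "measured", "known", "first", "only" and "open" are said of these compounds alone.

Compound 1, `CC1=CC[C@H](C(C)(C)NC(=S)N/N=C/c2ccccc2)CC1`, in a functional assay on UACC-62 cells (Homo sapiens) for inhibition, read by sulforhodamine B assay, with a stated time of 48 h (on this read-out lower numbers stand for stronger inhibition of growth and higher numbers for weaker inhibition of growth), gives a limit of the assay, > 100000 nM.
Compound 2, `CC1=CC[C@H](C(C)(C)NC(=S)N/N=C/c2ccc(F)cc2)CC1`, in this assay likewise gives a limit, > 100000 nM.
Compound 3, `CC1=CC[C@H](C(C)(C)NC(=S)N/N=C/c2cccc(Cl)c2)CC1`, in this assay gives 39800 nM.

Compound 3 is the only one of the three with a number in this assay; the other two sit at a limit, as the limit of > 100000 nM in this assay, at which 2 of the 3 values shown sit, records. Compound 4, `CC1=CC[C@H](C(C)(C)NC(=S)N/N=C/c2cccc([N+](=O)[O-])c2)CC1`, has not been measured. It differs from compound 3 by nitro in place of chloro on an aromatic carbon.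

Among the measured compounds shown here, no measured step exchanges chloro for nitro, so the evidence is indirect. The step of an at least 2.5-fold lower number from compound 1 to compound 3 (0.40 log units; beyond the scatter) shows that placing chloro on the aromatic ring turns a limit into a number, and an at least 2.5-fold lower number from compound 2 to compound 3 (0.40 log units; beyond the scatter) shows the same against the fluoro analogue, though both sizes are lower bounds because of the limit of > 100000 nM in this assay, at which 2 of the 3 values shown sit. The step that the two limits leave unreadable from compound 1 to compound 2 cannot be read at all. Whether a nitro group at the same place keeps the number that chloro gave is not known from these compounds.

On that basis compound 4 is expected to stay close to compound 3, with a step of a 1.1-fold higher number from compound 3 to compound 4 (0.05 log units; within the scatter) lying within the scatter, while a return to the limit remains quite possible. Compound 4 is therefore estimated at 45000 nM in this assay, with a range from 15000 nM to 100000 nM.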

Compound 4, concentration for total growth inhibition: > 100000 nM
Compound 4 ended at the assay's limit (the forecaster's own chance of this, stated with the estimate: 35%); middle value at least 2.2-fold (0.34 log units) from the limit.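

In this assay, nitro does not stand in for chloro on this aromatic carbon, meta to a large group: the exchange gives an at least 2.5-fold higher number from compound 3 to compound 4 (0.40 log units; beyond the scatter). Compound 4 records a limit of the assay rather than a number, so a group at this place does not by itself yield a measurable value, and among the compounds shown only the chloro group of compound 3 does. The step from hydrogen to nitro and the other steps between two limits cannot be read, and the step from chloro to nitro is only a lower bound because its upper end rests on a limit shared by most of the series: the limit of > 100000 nM in this assay, at which 3 of the 4 values shown sit.

As far as these compounds go, what stays open is whether the number belongs to chloro in particular or would also appear with bromo, methyl or trifluoromethyl at this place. The compounds shown also leave unknown how far past the limit compound 4 lies, and what an amine or a carboxylic acid on the same aromatic carbon would give against the value of compound 3.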